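A few compounds are considered here, and "the series" means these few. Any claim that something is new, unique, unknown or untested is made for them only; others in the source may bear on it.

Of the compounds shown here, three of one series have been tested in a functional assay on A549 cells (Homo sapiens) for cytotoxicity, read by MTT assay; a lower number here means a stronger inhibitor, a higher number a weaker inhibitor. Compound 1 `CCn1cc(-c2nnc(COc3cccc4ccccc34)o2)c(=O)c2cc(F)c(N3CCNCC3)cc21` gives 127 ug/mL. Compound 2 `CCn1cc(-c2nnc(Cc3ccccc3)o2)c(=O)c2cc(F)c(N3CCNCC3)cc21` differs from compound 1 by phenyl in place of (naphthalen-1-yl)oxy on a saturated chain carbon bound to an aromatic carbon; in this assay compound 2 gives 118 ug/mL, a step of a 1.1-fold lower number from compound 1 to compound 2 (0.03 log units; within the scatter). Compound 3 `O=c1c(-c2nnc(COc3cccc4ccccc34)o2)cn(C2CC2)c2cc(N3CCNCC3)c(F)cc12` differs from compound 1 in another place, by cyclopropyl in place of ethyl on an aromatic nitrogen; in this assay compound 3 gives 96.2 ug/mL, a step of a 1.3-fold lower number from compound 1 to compound 3 (0.12 log units; within the scatter). All three numbers lie within the usual scatter of one another, so none of the three can be called stronger or weaker than the others on this evidence.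

Compound 4 `O=c1c(-c2nnc(Cc3ccccc3)o2)cn(C2CC2)c2cc(N3CCNCC3)c(F)cc12` has not been measured in this assay. It differs from compound 3 by phenyl in place of (naphthalen-1-yl)oxy on a saturated chain carbon bound to an aromatic carbon, which is the same change already seen from compound 1 to compound 2, made on the core of compound 3 rather than the core of compound 1; the two cores differ by cyclopropyl in place of ethyl on an aromatic nitrogen. The place where the change is made reads the same in both cases.

Because that earlier change gave a step of a 1.1-fold lower number from compound 1 to compound 2 (0.03 log units; within the scatter), and because compound 3 gives 96.2 ug/mL, compound 4 is expected to sit close to compound 3, with an estimated step of a 1.1-fold lower number from compound 3 to compound 4 (0.04 log units; within the scatter). Compound 4 is estimated at 88 ug/mL in this assay, with a likely range from 50 ug/mL to 160 ug/mL.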

Compound 4, half-maximal inhibitory concentration: 86 ug/mL
Compound 4: middle estimate off by 1.0-fold (0.01 log units), on the high side; the range from low to high includes it.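

In this assay, putting phenyl in place of (naphthalen-1-yl)oxy on the core of compound 3 gives a 1.1-fold lower number from compound 3 to compound 4 (0.05 log units; within the scatter), and this agrees with the same change on the core of compound 1: the same change on two cores in this assay, a 1.1-fold lower number (0.03 log units; within the scatter) from compound 1 to compound 2 and a 1.1-fold lower number (0.05 log units; within the scatter) from compound 3 to compound 4, 1.0-fold (0.02 log units) apart, within the scatter of two such steps. Read the other way round, cyclopropyl in place of ethyl on an aromatic nitrogen gives a 1.4-fold lower number from compound 2 to compound 4 (0.14 log units; within the scatter), and this agrees with the same change made on the compounds that carry the (naphthalen-1-yl)oxy group: the same change on two cores in this assay, a 1.3-fold lower number (0.12 log units; within the scatter) from compound 1 to compound 3 and a 1.4-fold lower number (0.14 log units; within the scatter) from compound 2 to compound 4, 1.0-fold (0.02 log units) apart, within the scatter of two such steps. These four compounds therefore show that neither change moves the number by more than the scatter on either core, but because every step is so small, they do not show that a change with a real effect would carry over from one core to another, and they give no sign of what either group does on its own.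

The compounds shown leave open whether an amine or a carboxylic acid in place of phenyl on that saturated chain carbon, or a longer chain in place of ethyl or cyclopropyl on the aromatic nitrogen, would give a step beyond the scatter. If one did, whether that step would keep its size on both cores would remain a separate question.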